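A few compounds are considered here, and "the series" means these few. Any claim that something is new, unique, unknown or untested is made for them only; others in the source may bear on it.

Of the compounds shown here, two built on the same core have been tested in a functional assay on NCI/ADR-RES cells (Homo sapiens) for inhibition, read by sulforhodamine B assay, with a stated time of 48 h; a higher number here means a weaker inhibitor of growth, a lower number a stronger inhibitor of growth. Compound 1 `COc1cc(-c2nn(-c3cccc(NC(=O)c4ccc(Cl)c(C(F)(F)F)c4)c3)cc2-c2ccncc2)ccc1Cl` gives 11200 nM. Compound 2 `COc1cc(-c2nn(-c3cccc(NC(=O)Nc4ccc(Cl)c(C(F)(F)F)c4)c3)cc2-c2ccncc2)ccc1Cl` gives 7990 nM. Among the compounds with values here, on these numbers compound 2 has the lower of the two, yet the one measured step, a 1.4-fold lower number from compound 1 to compound 2 (0.15 log units; within the scatter), is within the scatter, so the two compounds cannot be told apart. Compound 3 `COc1cc(-c2nn(-c3cccc(NC(=O)c4ccccc4)c3)cc2-c2ccncc2)ccc1Cl` has not been measured. It differs from compound 2 by phenyl in place of (4-chloro-3-(trifluoromethyl)phenyl)amino on a carbonyl carbon. Within the data shown here, the only step known at this place on the carbonyl carbon, a 1.4-fold lower number from compound 1 to compound 2 (0.15 log units; within the scatter), was within the scatter; it exchanged one link for another while keeping the chloro and trifluoromethyl groups, whereas the change to compound 3 removes those groups as well, so that step is only a loose guide. The step of a 1.9-fold higher number from compound 2 to compound 3 (0.27 log units; within the scatter) is therefore expected to be modest, leaning toward a higher number. Compound 3 is estimated at 15000 nM, with a range from 5000 nM to 45000 nM.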

Compound 3, concentration for total growth inhibition: > 100000 nM
Compound 3 was reported as a limit (the forecaster's own chance of this, stated with the estimate: 10%); middle value at least 6.6-fold (0.82 log units) away from the limit.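

The earlier step, a 1.4-fold lower number from compound 1 to compound 2 (0.15 log units; within the scatter), changed only the link to the substituted ring and kept the chloro and trifluoromethyl groups, so it said little about those groups. The cleanest comparison here is an at least 8.9-fold higher number from compound 1 to compound 3 (0.95 log units; beyond the scatter), where the 4-chloro-3-(trifluoromethyl)phenyl on the carbonyl carbon gives way to plain phenyl, and an at least 12-fold higher number from compound 2 to compound 3 (1.09 log units; beyond the scatter) points the same way, so at this place in these compounds the substituted ring matters far more than the link. Compound 3 is reported only as a limit, not as a number, so the full size of both steps stays unknown: the limit of > 100000 nM in this assay, at which 1 of the 3 values shown sits.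

The compounds shown carry either both the chloro and trifluoromethyl groups or neither, so it remains open whether one alone would be enough. As far as these compounds go, it is also open whether a different group on that phenyl, such as a methyl or a nitrile, could take their place.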